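Propargyl to allyl: testing the ethynyl gain

This account rests on a few compounds, and the source may have more. Where it says the series, first, only, none or still open, it means among the compounds named here.

Going by the values given here, in a functional assay on NCI-H292 cells (Homo sapiens) for inhibition, read by MTT assay, with a stated time of 72 h (a higher number here means a weaker inhibitor, a lower number a stronger inhibitor), compound 3 `C#CCO[C@@H]1C=CC(=O)[C@@H](CO)O1` gives 6600 nM, the lowest number so far. Compound 1 `CCCO[C@@H]1C=CC(=O)[C@@H](CO)O1` gives 15600 nM, and compound 2 `O=C1C=C[C@@H](OC2CCCC2)O[C@@H]1CO` gives 19800 nM. Compound 4 `C=CCO[C@@H]1C=CC(=O)[C@@H](CO)O1` differs from compound 3 by vinyl in place of ethynyl on a saturated chain carbon bound to an oxygen on a saturated carbon. The closest measured change, at the same place, is a 2.4-fold lower number from compound 1 to compound 3 (0.37 log units; beyond the scatter). Also relevant are a 3.0-fold lower number from compound 2 to compound 3 (0.48 log units; beyond the scatter) and a 1.3-fold higher number from compound 1 to compound 2 (0.10 log units; within the scatter). Vinyl has a double bond, between the ethyl and ethynyl cases, so part of a 2.4-fold lower number from compound 1 to compound 3 (0.37 log units; beyond the scatter) is expected to be lost in this assay. The expected step is a 1.5-fold higher number from compound 3 to compound 4 (0.18 log units; within the scatter). Compound 4 is estimated at 10000 nM, with an expected range of 5500 nM to 18000 nM.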

Compound 4, half-maximal inhibitory concentration: 10300 nM
Compound 4: the middle estimate sits 1.0-fold (0.01 log units) below what was measured, within the range that was stated.
By their numbers in this assay, from the lowest: compounds 3, 4, 1 and 2 (each within the scatter of the next, the first and the last beyond it).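

In this assay allyl cannot be separated from any other ether at this position: the steps to it from propargyl (a 1.6-fold higher number from compound 3 to compound 4 (0.19 log units; within the scatter)), propyl (a 1.5-fold lower number from compound 1 to compound 4 (0.18 log units; within the scatter)) and cyclopentyl (a 1.9-fold lower number from compound 2 to compound 4 (0.28 log units; within the scatter)) all lie within the scatter. Compound 4 thus overlaps both compound 3 and compound 1, though those two stand apart, so the data do not settle whether a double bond keeps any of the ethynyl gain. No supporting measurement explains these differences.

Still open, going by these compounds, is whether a longer chain ending in ethynyl keeps the value of compound 3 (6600 nM). An amine or a carboxylic acid at the end of the chain is also untested in the compounds shown here.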